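Methyl for methoxy on the aryl ketone: compound 4

The source may hold more compounds than are shown below. What is called first, only, known or untested is meant among the compounds shown, and "the series" means these compounds.

Measured so far:
compound 1, `COC(=O)c1c(Nc2ccc(Cl)cc2)sc(C(=O)c2ccc(OC)cc2)c1C` — "not active" (no number reported)
compound 2, `COc1ccc(C(=O)c2sc(Nc3ccccc3)c(C(=O)O)c2C)cc1` — 19.6%
compound 3, `COc1ccc(C(=O)c2sc(Nc3ccc(Cl)cc3)c(C(=O)O)c2C)cc1` — "not active" (no number reported)
to be measured: compound 4, `Cc1ccc(C(=O)c2sc(Nc3ccc(Cl)cc3)c(C(=O)O)c2C)cc1`

In a functional assay, with a stated time of 150 min, tested at 5 ug/mL (a lower number here means a weaker effect, a higher number a stronger effect of the compound at the concentration tested), compound 2 gives 19.6%, a weak effect at the concentration tested. Compound 1 is reported only as "not active" (no number reported), without a number. Compound 3 is likewise reported as "not active" (no number reported) and so has no single number; one further compound of the set, compound 1, also has none. For the measured compounds named here, compound 3 thus stands without a numeric reading, and the only number in the set, that of compound 2, is low.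

Compound 4 differs from compound 3 in one place: methyl in place of methoxy on an aromatic carbon. Going by the values given here, no measured pair shows this change, so its step size is not known from the data. Since compound 3 has no number in this assay and compound 2 shows only a weak effect, the step from compound 3 to compound 4 is expected to be small, none beyond the scatter, in either direction. Compound 4 is therefore expected to give about 8%, in the range 0% to 22%, and a report without a number is about as likely as a number.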

Compound 4, a percentage reported as activity, at one concentration (the size of the read-out at that concentration, not a potency): "not active" (no number reported)
Compound 4 has no reported number here; no gap can be computed for the estimate.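

In this assay compound 3 gives "not active" (no number reported) and compound 4 gives "not active" (no number reported) so no step can be read between them. No data at hand bear on this result. The compounds shown leave open what the change from 4-methoxyphenyl to 4-methylphenyl does on a compound that gives a numeric reading.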